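The compounds below may be only part of what the source reports. "The series", "measured", "known", "first", "only" and "open" are said of these compounds alone.

Compound 1, with structure `COc1ccc(-c2cc(/C=C/C(=O)c3ccc(N)cc3)[nH]n2)cc1`, belongs to a pair of enone compounds whose cytotoxic effect was examined in a functional assay on OVCAR-3 cells (Homo sapiens) for cytotoxicity, read by sulforhodamine B assay, with a stated time of 48 h, tested at 100 uM; on this read-out higher numbers stand for a weaker effect at the one concentration tested and lower numbers for a stronger effect. In this assay compound 1 gives -85%. Its partner, compound 2, has structure `COc1ccc(C(=O)/C=C/c2cc(-c3cc(OC)c(OC)c(OC)c3)n[nH]2)cc1`; in this assay compound 2 gives -69%. Compound 1 therefore stands at the lowest of the two numbers, and the gap to compound 2 lies beyond the usual scatter of such measurements, so compound 1 shows the stronger effect of the two at this concentration.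

The unmeasured compound 3, with structure `COc1ccc(-c2cc(/C=C/C(=O)c3ccc(N)cc3)[nH]n2)cc1OC`, differs from compound 1 in a single place: methoxy in place of hydrogen on an aromatic carbon. Among the compounds with values here, no step between two measured compounds of this set traces a change of this kind on its own, so nothing measured here points to a direction for it. The step expected from compound 1 to compound 3 in this assay is a number 7 percentage points higher from compound 1 to compound 3 (within the scatter), a change that would stay within the scatter. On that basis compound 3 is estimated to give -78%, within a range from -95% to -55%.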

Compound 3, a percentage reported as activity, at one concentration (the size of the read-out at that concentration, not a potency): -99%
Beside the measured number, compound 3's estimate is 21 percentage points above it; measured number outside the range, below it.
By their numbers in this assay, from the lowest: compound 3; then compound 1; then compound 2.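

Methoxy in place of hydrogen, on an aromatic carbon ortho to a methoxy group and meta to a large group, gives a number 14 percentage points lower from compound 1 to compound 3 (beyond the scatter) in this assay, the first change in this set that can be read on its own. It shows that this position of the six-membered aromatic ring accepts the added methoxy, and that the effect at the one concentration tested grows stronger rather than being kept or lost. No measurement at hand bears on why the number moves in this direction.

Within the data shown here, the single step does not show whether the gain belongs to methoxy itself, since a hydroxy group, an ethoxy group or a fluorine on the same carbon would be needed to separate it from other substituents. It also leaves open whether the same change would hold on a compound whose amine is replaced, for instance by a nitro group or a dimethylamino group, and how the step would look as a potency rather than as a read-out at one concentration.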